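Acetamido in Place of Propanoyloxy: What to Expect

The compounds below may be only part of what the source reports. "The series", "measured", "known", "first", "only" and "open" are said of these compounds alone.

Measured compounds so far:
compound 1 `CC(=O)OCc1ccc2oc(=O)c(C(=O)Oc3cccc(Cl)c3)cc2c1` — 6.17%
compound 2 `CC(=O)OCc1ccc2oc(=O)c(C(=O)Sc3cccc(Br)c3)cc2c1` — 67.8%
compound 3 `CCC(=O)OCc1ccc2oc(=O)c(C(=O)Oc3cccc(Br)c3)cc2c1` — 21.3%

In a functional assay on HT-1080 cells (Homo sapiens), read by transwell migration, with a stated time of 24 h, tested at 10 uM (a lower number here means a stronger effect, a higher number a weaker effect of the compound at the concentration tested), compound 1 gives 6.17%, compound 2 gives 67.8%, and compound 3 gives 21.3%. Compound 3 therefore stands second highest of the three; it is nearest to compound 1, whose number lies lower by a margin beyond the scatter, and furthest from compound 2, whose number lies higher, also beyond the scatter. Going by the values given here, the only step between single-change neighbours, a number 61.6 percentage points higher from compound 1 to compound 2 (beyond the scatter), concerns the (3-bromophenyl)sulfanyl in place of 3-chlorophenoxy on a carbonyl carbon and leaves the side chain on the aromatic ring untouched.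

Compound 4 `CC(=O)NCc1ccc2oc(=O)c(C(=O)Oc3cccc(Br)c3)cc2c1` carries the change (acetamido in place of propanoyloxy on a saturated chain carbon bound to an aromatic carbon). Among the compounds with values here, no measured pair differs at this position, so nothing among the data speaks directly to its effect; the one known step touches another part of the molecule. Compound 4 is therefore expected to lie near compound 3, with a number 3.7 percentage points higher from compound 3 to compound 4 (within the scatter) judged as no change beyond the scatter. For compound 4 the estimate in this assay is 25%, between 5% and 55%.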

Compound 4, a percentage reported as activity, at one concentration (the size of the read-out at that concentration, not a potency): 27.1%
For compound 4 the middle estimate is 2.1 percentage points below the measured one; the range from low to high includes it.
By their numbers in this assay, from the lowest: compound 1; then compounds 3 and 4 (each within the scatter of the next); then compound 2.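

In this assay, going by these compounds alone, this is the first pair that differs at this position, and a number 5.8 percentage points higher from compound 3 to compound 4 (within the scatter) shows that acetamido can stand in place of propanoyloxy on a saturated chain carbon bound to an aromatic carbon without a change beyond the scatter. The exchange replaces a group of 5 heavy atoms with 0 hydrogen-bond donors by one of 4 heavy atoms with 1 hydrogen-bond donor, and it brings in nitrogen, yet this single pair shows nothing like the large earlier step, a number 61.6 percentage points higher from compound 1 to compound 2 (beyond the scatter), which lay on a carbonyl carbon at the other end of the molecule. No measurement is available that could explain why the two side chains read alike.

The compounds shown leave open whether other groups at this place, such as a free aminomethyl group, a carboxylic acid or a longer acyl chain such as hexanoyloxy, would also stay within the scatter of compound 3. They also leave open whether acetamido would behave the same way with the (3-bromophenyl)sulfanyl group on the carbonyl carbon, since this change has been read in one pair only.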